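The source may report more compounds than this note shows. Statements on the series, on what has been measured and on what is new or still open speak of the compounds shown alone.

In a functional assay on MV4-11 cells (Homo sapiens) for cytotoxicity, read by colorimetric assay and MTT assay, with a stated time of 3 days, tested at 20 uM (on this read-out higher numbers stand for a weaker effect at the one concentration tested and lower numbers for a stronger effect), compound 1 `COc1ccc(-c2nc(-c3ccccc3)c(-c3ccc4c(c3)NC(=O)CO4)[nH]2)cc1` gives 1.2%. That is the lowest of the three numbers recorded in this assay. Compound 2 `O=C1COc2ccc(-c3nn(-c4ccc(Br)cc4)cc3-c3ccccc3)cc2N1` gives 91.5% and compound 3 `O=C1COc2ccc(-c3nn(-c4cc(Cl)cc(Cl)c4)cc3-c3ccccc3)cc2N1` gives 50.5%, so compound 1 stands well apart from both, beyond the scatter in each case.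

Compound 4 `O=C1COc2ccc(-c3[nH]c(-c4ccc(C(F)(F)F)cc4)nc3-c3ccccc3)cc2N1` differs from compound 1 in one place: trifluoromethyl in place of methoxy on an aromatic carbon. The change sits on an aromatic carbon of a six-membered aromatic ring of carbon only, para to a large group; cut one bond further out it reads 4-methoxyphenyl to 4-(trifluoromethyl)phenyl.

Within the data shown here, only one measured step exists, a number 41 percentage points lower from compound 2 to compound 3 (beyond the scatter), and it concerns 3,5-dichlorophenyl in place of 4-bromophenyl on an aromatic nitrogen of a different core. It shows that changing a substituent on an aryl ring can move this read-out a long way, but it says nothing direct about trifluoromethyl in place of methoxy on the core of compound 1. Among the measured compounds shown here, no measured pair exchanges these two groups.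

With compound 1 already near the bottom of the scale, the expected step from compound 1 to compound 4 is a number 13.8 percentage points higher from compound 1 to compound 4 (beyond the scatter), upward, though it may well stay within the scatter. Compound 4 is therefore estimated at 15%, within a range of 1% to 60%.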

Compound 4, a percentage reported as activity, at one concentration (the size of the read-out at that concentration, not a potency): 0.6%
Estimate against measurement, compound 4: 14.4 percentage points above; measured number below the stated range.
By their numbers in this assay, from the lowest: compounds 4 and 1 (each within the scatter of the next); then compound 3; then compound 2.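

In this assay, trifluoromethyl in place of methoxy on an aromatic carbon of the core of compound 1, para to a large group, gives a number 0.6 percentage points lower from compound 1 to compound 4 (within the scatter). The earlier compounds shown here showed only that an aryl substituent on a different core can move this read-out a long way, whereas here the strong effect at the one concentration tested survives the exchange, so at this place it does not rest on the hydrogen-bond acceptor counted for methoxy, and the larger group is accepted. No measurement at hand bears on why these two groups read alike.

The compounds shown leave open whether the two would still read alike at lower concentrations, since both lie near the bottom of the scale at a single concentration and this read-out gives no potency. They also leave open how far this place accepts other kinds of group, such as an amine, a carboxylic acid or a longer chain like butoxy, any of which could show whether the effect holds beyond the two groups seen here.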